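The compounds below may be only part of what the source reports. "The series", "measured", "known", "first", "only" and "open" are said of these compounds alone.

Among the measured compounds shown here, compound 2, `O=C1N=C(N2CCC[C@H]2C(=O)Nc2ccc3ncnc(Nc4cccc(Cl)c4)c3c2)S/C1=C/c1cccc(Br)n1`, holds the only numerical value: in a functional assay on A549 cells (Homo sapiens) for antiproliferative activity, read by MTT assay (a higher number here means a weaker inhibitor, a lower number a stronger inhibitor), compound 2 gives 3100 nM. Compound 1, `O=C1N=C(N2CCC[C@H]2C(=O)Nc2ccc3ncnc(Nc4cccc(Cl)c4)c3c2)S/C1=C/c1ccccc1Br`, reaches only a limit in this assay, > 50000 nM, as noted in the limit of > 50000 nM in this assay, at which 1 of the 2 values shown sits. For the measured compounds named here, the single measured step is an at least 16-fold lower number from compound 1 to compound 2 (1.20 log units; beyond the scatter). Compound 3, `O=C1N=C(N2CCC[C@H]2C(=O)Nc2ccc3ncnc(Nc4cccc(Cl)c4)c3c2)S/C1=C/c1cccc(Br)c1`, carries 3-bromophenyl in place of 6-bromopyridin-2-yl on a double-bonded chain carbon bound to a double-bonded ring carbon. This change returns a carbon-only ring of the kind found in compound 1 while retaining the bromine, so a weaker result than compound 2 is expected. The expected change is estimated as a 3.9-fold higher number from compound 2 to compound 3 (0.59 log units; beyond the scatter), which is smaller than the measured step. Compound 3 is therefore estimated at 12000 nM, in the range 3000 nM to 50000 nM.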

Compound 3, half-maximal inhibitory concentration: > 50000 nM
Compound 3 ended at the assay's limit; the forecaster's own chance of this, stated with the estimate: 25%; middle value at least 4.1-fold (0.61 log units) away from the limit.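

In this assay, 3-bromophenyl in place of 6-bromopyridin-2-yl gives an at least 16-fold higher number from compound 2 to compound 3 (1.20 log units; beyond the scatter). Moving the bromine on a carbon-only ring therefore does not reach the level of compound 2, and at this position only the ring with a hetero atom gives a readable number so far. The step from compound 1 to compound 3 cannot be read, as both values are limits of the assay: the limit of > 50000 nM in this assay, at which 2 of the 3 values shown sit.

Still open, on these data alone, is whether the ring nitrogen alone carries this gain, or whether a pyridin-2-yl without bromine, or one bearing an amine in its place, would hold it.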